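The source may report more compounds than this note shows. Statements on the series, on what has been measured and on what is new or still open speak of the compounds shown alone.

Compound 1 `O=C(CSc1nnc(-c2ccncc2)n1-c1ccccc1)N/N=C/c1ccc(O)cc1`, in a functional assay on HCT-116 cells (Homo sapiens) for inhibition, read by MTT assay, with a stated time of 48 h (a lower number here means a stronger inhibitor, a higher number a weaker inhibitor), gives > 50000 nM, which is a limit of the assay and not a number.
Compound 2 `O=C(CSc1nnc(-c2ccncc2)n1-c1ccccc1)N/N=C/c1ccc(Cl)cc1` gives 5740 nM in this assay.
Compound 3 `O=C(CSc1nnc(-c2ccncc2)n1-c1ccccc1)N/N=C/c1ccc(F)cc1` gives 7040 nM in this assay.

Among the two numbers shown, compound 3 has the higher one, though its nearest neighbour compound 2 sits within the scatter: the step of a 1.2-fold higher number from compound 2 to compound 3 (0.09 log units; within the scatter) is too small to count as a difference. The other measured steps are larger. Replacing hydroxy with chloro gave an at least 8.7-fold lower number from compound 1 to compound 2 (0.94 log units; beyond the scatter), and replacing hydroxy with fluoro gave an at least 7.1-fold lower number from compound 1 to compound 3 (0.85 log units; beyond the scatter), in both cases from a value that is only a limit (the limit of > 50000 nM in this assay, at which 1 of the 3 values shown sits).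

Compound 4 `O=C(CSc1nnc(-c2ccncc2)n1-c1ccccc1)N/N=C/c1cc(Br)cc(Br)c1O` brings a hydroxy group back, together with two bromines: 3,5-dibromo-2-hydroxyphenyl in place of 4-fluorophenyl on a carbon with a double bond to nitrogen. Within the data shown here, the one step that bears on it is the one from compound 1 to compound 3, where removing hydroxy in favour of fluoro lowered the number beyond the scatter. Reversing that direction, a higher number is expected for compound 4 in this assay, a step of a 2.6-fold higher number from compound 3 to compound 4 (0.41 log units; beyond the scatter). The estimate for compound 4 is 18000 nM, between 5000 nM and 50000 nM, with a real chance that only a limit is reported.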

Compound 4, half-maximal inhibitory concentration: 4500 nM
Compound 4: the middle estimate sits 4.0-fold (0.60 log units) above what was measured; measured number below the stated range.
By their numbers in this assay, from the lowest: compounds 4, 2 and 3 (each within the scatter of the next). At a limit, above all of these: compound 1.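

In this assay the 3,5-dibromo-2-hydroxyphenyl group on the carbon with a double bond to nitrogen cannot be told apart from 4-fluorophenyl or 4-chlorophenyl, with a 1.6-fold lower number from compound 3 to compound 4 (0.19 log units; within the scatter) and a 1.3-fold lower number from compound 2 to compound 4 (0.11 log units; within the scatter) as its two steps. A hydroxy group on this ring therefore does not on its own hold the number at the limit: compound 4 carries one and stays clear of it, while compound 1 carries one and does not. Against 4-hydroxyphenyl the new group gives an at least 11-fold lower number from compound 1 to compound 4 (1.04 log units; beyond the scatter) and that step starts from a value that is only a limit: the limit of > 50000 nM in this assay, at which 1 of the 4 values shown sits.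

The two bromines and the hydroxy group enter together, so the compounds shown cannot separate what each one contributes. From the compounds shown here alone, how a ring bearing an amine, a carboxylic acid or a methoxy group would read at this position stays open.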